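Replacing a Substituted Pyrazole with Indazole in Glucagon Antagonists

The source may report more compounds than this note shows. Statements on the series, on what has been measured and on what is new or still open speak of the compounds shown alone.

Measured compounds:
compound 1 `CCCC(Oc1ccc(-n2cc(Cl)cn2)cc1)c1ccc(C(=O)NCCC(=O)O)cc1`: 6500 nM
compound 2 `CCCC(Oc1ccc(-n2cccn2)cc1)c1ccc(C(=O)NCCC(=O)O)cc1`: > 55000 nM
compound 3 `CCCC(Oc1ccc(-n2cc(C(F)(F)F)cn2)cc1)c1ccc(C(=O)NCCC(=O)O)cc1`: 5100 nM

All three share a core in which an aryl ether carries a five-membered aromatic ring with two nitrogens. In a functional assay on cells for antagonist activity at Glucagon receptor (Homo sapiens), read by cAMP accumulation, in the presence of a further agent that is not named here (a higher number here means a weaker inhibitor, a lower number a stronger inhibitor), compound 3 gives 5100 nM, the lowest of the two numbers, with compound 1 at 6500 nM close beside it: a 1.3-fold lower number from compound 1 to compound 3 (0.11 log units; within the scatter). Compound 2 gives only a limit, > 55000 nM, marked by the limit of > 55000 nM in this assay, at which 1 of the 3 values shown sits.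

Compound 4 `CCCC(Oc1ccc(-n2cc3ccccc3n2)cc1)c1ccc(C(=O)NCCC(=O)O)cc1` is unmeasured. It differs from compound 3 by 2H-indazol-2-yl in place of 4-(trifluoromethyl)-1H-pyrazol-1-yl on an aromatic carbon.

Within the data shown here, two measured steps bear on this. Removing the substituent gave an at least 8.4-fold higher number from compound 1 to compound 2 (0.92 log units; beyond the scatter), and restoring a group at that carbon gave an at least 10-fold lower number from compound 2 to compound 3 (1.03 log units; beyond the scatter). Both substituted pyrazoles sit within scatter of each other, so the ring seems to tolerate different groups there, while the bare ring falls to the limit. The entering 2H-indazol-2-yl brings a six-membered aromatic ring of carbon only, so compound 4 is expected to behave like the substituted compounds rather than compound 2. The estimate for compound 4 is 5500 nM, between 1500 nM and 25000 nM, meaning an expected step of a 1.1-fold higher number from compound 3 to compound 4 (0.03 log units; within the scatter).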

Compound 4, antagonist equilibrium constant: 2000 nM
Estimate against measurement, compound 4: 2.8-fold (0.44 log units) above, and the stated range covers the measured number.
By their numbers in this assay, from the lowest: compound 4; then compounds 3 and 1 (each within the scatter of the next). At a limit, above all of these: compound 2.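

Among these compounds, the step to compound 4 (a 2.6-fold lower number from compound 3 to compound 4 (0.41 log units; beyond the scatter)) and the one from the chloro analogue (a 3.3-fold lower number from compound 1 to compound 4 (0.51 log units; beyond the scatter)) both lie beyond the scatter in this assay, so this position can do more than tolerate a substituted pyrazole. The 2H-indazol-2-yl group, with its six-membered aromatic ring of carbon only, makes compound 4 the strongest inhibitor of the four, whereas 4-chloro-1H-pyrazol-1-yl and 4-(trifluoromethyl)-1H-pyrazol-1-yl could not be told apart. Neither a chloro nor a trifluoromethyl group is therefore needed here, and the step from unsubstituted 1H-pyrazol-1-yl (an at least 27-fold lower number from compound 2 to compound 4 (1.43 log units; beyond the scatter)) starts from a limit of the assay rather than a number: the limit of > 55000 nM in this assay, at which 1 of the 4 values shown sits.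

As far as these compounds go, it remains open whether a chloro group, a trifluoromethyl group, a methoxy group or an amine on the six-membered aromatic ring of 2H-indazol-2-yl would lower the number further or raise it. Also unknown is whether the advantage of 2H-indazol-2-yl would persist with a longer chain on the shared core or with a group other than the carboxylic acid at its end.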